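A few compounds are considered here, and "the series" means these few. Any claim that something is new, unique, unknown or untested is made for them only; others in the source may bear on it.

Measured in a functional assay on MDA-MB-435 cells (Homo sapiens) for inhibition; a lower number here means a stronger inhibitor, a higher number a weaker inhibitor:

Compound 1 `O=C(/C=C/c1ccc(I)cc1)c1ccc(OCB(O)O)cc1`: 18000 nM
Compound 2 `O=C(/C=C/c1ccc(I)cc1)c1ccc(O)cc1`: 4500 nM
Compound 3 `O=C(O)COc1ccc(/C=C/C(=O)c2ccc(Cl)c(Cl)c2)cc1`: 13000 nM

Compound 3 stands second highest of the three numbers. Its nearest neighbour is compound 1, whose number is slightly higher, a gap within the usual scatter; compound 2 sits furthest away with a lower number, a gap beyond the scatter.

Compound 4 `O=C(/C=C/c1ccc(B(O)O)cc1)c1ccc(Cl)c(Cl)c1` differs from compound 3 in one place: a group of 3 heavy atoms (1 boron, 2 oxygen; no ring) in place of a group of 5 heavy atoms (2 carbon, 3 oxygen; no ring), on an aromatic carbon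

Among the measured compounds shown here, only one measured step bears on this change, and only loosely. From compound 1 to compound 2 the number fell by a 4.0-fold lower number from compound 1 to compound 2 (0.60 log units; beyond the scatter) when a boron-bearing group left an oxygen. In the present step a boron-bearing group enters instead, but on an aromatic carbon, and what leaves is carboxymethoxy rather than a hydrogen, so the earlier step is not a direct guide. Taken at face value its direction points to a somewhat higher number for compound 4, yet the mismatch of leaving group and place argues for caution. The expected step from compound 3 to compound 4 is therefore small, a 1.2-fold higher number from compound 3 to compound 4 (0.09 log units; within the scatter), near the edge of the scatter. Compound 4 is estimated at 16000 nM, with a range from 5000 nM to 50000 nM.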

Compound 4, half-maximal inhibitory concentration: 4000 nM
Estimate against measurement, compound 4: 4.0-fold (0.60 log units) above; the measured number lies below the stated range.
By their numbers in this assay, from the lowest: compounds 4 and 2 (each within the scatter of the next); then compounds 3 and 1 (each within the scatter of the next).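

In this assay, replacing carboxymethoxy with the group of boron and two oxygens, on an aromatic carbon para to a large group, gives a 3.3-fold lower number from compound 3 to compound 4 (0.51 log units; beyond the scatter), so carboxymethoxy is not needed at this position for the lower number, and a boron-bearing group attached directly to the ring carbon is compatible with it. Among the compounds shown here, the only earlier step involving boron, a 4.0-fold lower number from compound 1 to compound 2 (0.60 log units; beyond the scatter), went the other way: there the number fell when a boron-bearing group left an oxygen, so across these two steps the presence of boron does not by itself set the direction, though the steps also differ in place, in the group exchanged and in the rest of the structure. No measurement here explains the drop from compound 3 to compound 4.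

The step does not show whether the lower number comes from the arrival of the boron-bearing group or the departure of carboxymethoxy, which a plain hydrogen, a carboxylic acid or an amine on the same aromatic carbon, with the rest of compound 3 kept, could help to separate. From the compounds shown here alone, it also remains open whether the same exchange would act similarly on the iodine-bearing core of compound 1.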